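This account rests on a few compounds, and the source may have more. Where it says the series, first, only, none or still open, it means among the compounds named here.

The compounds share one core, and only the group attached to the amide differs among them. Compound 1 `O=C(CSc1nnc(-c2ccncc2)s1)NCc1ccc(Cl)cc1` has been examined in an ADME assay on BHK-21 cells (Mesocricetus auratus) for cytotoxicity, with a stated time of 3 days; a higher number here means that more compound is tolerated, a lower number that less compound is tolerated. In this assay compound 1 gives > 50000 nM, which is a limit of the assay rather than a number. For compound 1 the relevant observation is the limit of > 50000 nM in this assay, at which 1 of the 2 values shown sits. Compound 2 `O=C(CSc1nnc(-c2ccncc2)s1)Nc1c(Cl)cccc1Cl` is the starting point of the step followed here. In this assay compound 2 gives "not determined" (no result reported), so no number stands for it, and nothing shown places it against compound 1. Compound 3 `O=C(CSc1nnc(-c2ccncc2)s1)Nc1ccccc1Cl` differs from compound 2 by hydrogen in place of chloro on an aromatic carbon, in other words hydrogen in place of chloro on an aromatic carbon. Among the measured compounds shown here, no step between measured compounds that differ in one place is available, so the size of this step cannot be read from the data; the change is expected to move the tolerated concentration in this assay by no more than the usual scatter, with no particular direction favoured. Compound 3 is therefore estimated at 50000 nM in this assay, with a range from 20000 nM to 100000 nM, and the result may again come back only as a limit.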

Compound 3, half-maximal cytotoxic concentration: > 50000 nM
Compound 3 gave a limit, no number; the forecaster's own chance of this, stated with the estimate: 70%; the middle value sits exactly at the limit.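

In this assay compound 3 gives > 50000 nM as a limit of the assay and not a number. Compound 1 also stands at a limit, so no step can be read between compound 1 and compound 3. The compounds shown leave open, in this assay and for both compounds, where the half-maximal cytotoxic concentration actually lies, and how compound 2 compares with compound 3.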